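Adding a Fluorine to the Ester of Compound 3

The source may hold more compounds than are shown below. What is called first, only, known or untested is meant among the compounds shown, and "the series" means these compounds.

Of the compounds shown here, three sharing one core have been measured in a functional assay on MCF7 cells (Homo sapiens) for antiproliferative activity, read by MTT assay, with a stated time of 72 h; on this read-out higher numbers stand for weaker inhibition and lower numbers for stronger inhibition. Compound 1 `CC1=CC[C@H]2[C@H](CC[C@]2(C)O)C(C)(C)[C@@H]1CC[C@H]1[C@]2(C)CC[C@H](OC(=O)c3ccccc3)C(C)(C)O[C@H]2CC[C@@]1(C)O` gives 21000 nM. Compound 2 `CC1=CC[C@H]2[C@H](CC[C@]2(C)O)C(C)(C)[C@@H]1CC[C@H]1[C@]2(C)CC[C@H](OC(=O)NCc3ccccc3)C(C)(C)O[C@H]2CC[C@@]1(C)O` gives 24500 nM. Compound 3 `CC1=CC[C@H]2[C@H](CC[C@]2(C)O)C(C)(C)[C@@H]1CC[C@H]1[C@]2(C)CC[C@H](OC(=O)c3ccc(C(F)(F)F)cc3)C(C)(C)O[C@H]2CC[C@@]1(C)O` gives 23400 nM. Compound 3 stands alongside the other two, since a 1.1-fold higher number from compound 1 to compound 3 (0.05 log units; within the scatter) and a 1.0-fold lower number from compound 2 to compound 3 (0.02 log units; within the scatter) both fall within the scatter, so the three numbers cannot be separated on this read-out. Compound 4 `CC1=CC[C@H]2[C@H](CC[C@]2(C)O)C(C)(C)[C@@H]1CC[C@H]1[C@]2(C)CC[C@H](OC(=O)c3ccc(C(F)(F)F)cc3F)C(C)(C)O[C@H]2CC[C@@]1(C)O` has not yet been measured. The change from compound 3 to compound 4 is fluoro in place of hydrogen on an aromatic carbon. Among the compounds with values here, no measured step introduces a fluoro group; the closest step bearing on it is the addition of a trifluoromethyl group, a 1.1-fold higher number from compound 1 to compound 3 (0.05 log units; within the scatter), which stayed within the scatter, as did the larger swap a 1.2-fold higher number from compound 1 to compound 2 (0.07 log units; within the scatter). A single added fluorine on the aromatic ring is therefore expected to give no change at the digits printed from compound 3 to compound 4 (within the scatter) in this assay, with no direction beyond the scatter. Compound 4 is estimated to give 23400 nM, expected between 12000 nM and 47000 nM.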

Compound 4, half-maximal inhibitory concentration: > 50000 nM
Compound 4 ended at the assay's limit (the forecaster's own chance of this, stated with the estimate: 5%); middle value at least 2.1-fold (0.32 log units) away from the limit.
By their numbers in this assay, from the lowest: compounds 1, 3 and 2 (each within the scatter of the next). At a limit, above all of these: compound 4.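

In this assay compound 4 stands at a limit of the assay and not at a measured number: the limit of > 50000 nM in this assay, at which 1 of the 4 values shown sits.

Even so, a single fluoro group on this aromatic carbon, ortho to a large group and meta to a trifluoromethyl group, is the first one-place change in this set to go beyond the scatter, giving an at least 2.1-fold higher number from compound 3 to compound 4 (0.32 log units; beyond the scatter), whereas adding the trifluoromethyl group gave only a 1.1-fold higher number from compound 1 to compound 3 (0.05 log units; within the scatter). The wider comparisons read an at least 2.3-fold higher number from compound 1 to compound 4 (0.37 log units; beyond the scatter) and an at least 2.0-fold higher number from compound 2 to compound 4 (0.30 log units; that floor lies within the scatter).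

From the compounds shown here alone, how far compound 4 truly lies past the limit remains unknown. Also open, going by these compounds, is whether a chloro or methoxy group on this same carbon would weaken inhibition as well, and whether fluoro would do so on a ring lacking the trifluoromethyl group.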